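Fluoro for Methoxy on a Shared Core

The source may hold more compounds than are shown below. What is called first, only, known or untested is meant among the compounds shown, and "the series" means these compounds.

Compound 2 `COc1ccc2nc(Cl)c(/C=C3\SC(=S)NC3=O)cc2c1` was tested in a toxicity assay on THP-1 cells (Homo sapiens) for cytotoxicity, read by MTT assay, with a stated time of 48 h; on this read-out higher numbers stand for weaker inhibition of growth and lower numbers for stronger inhibition of growth. In this assay compound 2 gives > 100 ug/mL, which is a limit of the assay and not a number. Compound 1 `CCOc1ccc2nc(Cl)c(/C=C3\SC(=S)NC3=O)cc2c1` likewise gives > 100 ug/mL in this assay, again a limit rather than a number. The step that the two limits leave unreadable from compound 1 to compound 2 therefore cannot be read, since both values sit at the limit of > 100 ug/mL in this assay, at which 2 of the 2 values shown sit.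

The change to compound 3 `O=C1NC(=S)S/C1=C\c1cc2cc(F)ccc2nc1Cl` is fluoro in place of methoxy on an aromatic carbon. Within the data shown here, no measured step bears directly on this change: the only step available is unreadable and concerns a different group. With both measured values resting at the same limit, nothing in the data points to a step beyond the scatter in either direction. Compound 3 is expected to give about 100 ug/mL, between 40 ug/mL and 300 ug/mL. The expected step is a number no higher from compound 2 to compound 3 (the limit leaves the size open), most likely ending at the same limit.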

Compound 3, concentration for 50% growth inhibition: > 100 ug/mL
Compound 3 ended at the assay's limit; the forecaster's own chance of this, stated with the estimate: 75%; the middle value lies on the limit itself.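

Among these compounds, compound 3, like compound 1 and compound 2, gives only a limit and not a number in this assay, so no step among the three can be read: the limit of > 100 ug/mL in this assay, at which 3 of the 3 values shown sit. The compounds shown leave open whether ethoxy, methoxy and fluoro on the shared core differ at all in their inhibition of growth.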